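A few compounds are considered here, and "the series" means these few. Any claim that something is new, unique, unknown or untested is made for them only; others in the source may bear on it.

For the measured compounds named here, in a functional assay on HeLa cells (Homo sapiens) for inhibition, read by sulforhodamine B assay (on this read-out higher numbers stand for weaker inhibition and lower numbers for stronger inhibition), compound 3 `O=C1C(Nc2ccc(C(F)(F)F)cc2)=CC(=O)c2c1nc1n2[C@H]2OC[C@@H](O)[C@H]2OC1` gives 8920 nM, the higher of the two exact numbers so far, and compound 1 `O=C1C(Nc2ccc(I)cc2)=CC(=O)c2c1nc1n2[C@H]2OC[C@@H](O)[C@H]2OC1` gives 4010 nM. Compound 2 `O=C1C(N2CCCC2)=CC(=O)c2c1nc1n2[C@H]2OC[C@@H](O)[C@H]2OC1` gives > 16000 nM, which is a limit of the assay and not an exact number. Compound 4 `O=C1C(NC2CC2)=CC(=O)c2c1nc1n2[C@H]2OC[C@@H](O)[C@H]2OC1` is still unmeasured, and its difference is cyclopropyl in place of 4-(trifluoromethyl)phenyl on an amine nitrogen. Going by the values given here, the closest precedent also replaces an aromatic group with a non-aromatic ring, giving an at least 3.9-fold higher number from compound 1 to compound 2 (0.60 log units; beyond the scatter). Exchanging iodo for trifluoromethyl gave a smaller change, a 2.2-fold higher number from compound 1 to compound 3 (0.35 log units; beyond the scatter). A modest rise toward weaker inhibition is therefore expected, with the estimated step being a 2.1-fold higher number from compound 3 to compound 4 (0.33 log units; beyond the scatter). For compound 4, the estimated value is 19000 nM, within an expected range of 8000 nM to 45000 nM.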

Compound 4, half-maximal inhibitory concentration: > 16000 nM
Compound 4 gave a limit, no number; the forecaster's own chance of this, stated with the estimate: 50%; the middle value does not contradict the limit.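

Compound 4 keeps the hydrogen on the amine nitrogen that compound 2 lacks, yet with a non-aromatic ring in place of the 4-iodophenyl group, the result is an at least 3.9-fold higher number from compound 1 to compound 4 (0.60 log units; beyond the scatter). Against the 4-(trifluoromethyl)phenyl group the same ring gives only an at least 1.7-fold higher number from compound 3 to compound 4 (0.25 log units; that floor lies within the scatter), so this comparison alone establishes no real loss. Compound 2 and compound 4 both rest on a limit, so the step between them cannot be read: the limit of > 16000 nM in this assay, at which 2 of the 4 values shown sit.

On these data alone, how far above that limit these two compounds lie remains open. Also open, as far as these compounds go, is whether a longer chain, such as butyl, or a benzyl group on this amine nitrogen would give a readable number.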